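The source may report more compounds than this note shows. Statements on the series, on what has been measured and on what is new or still open speak of the compounds shown alone.

Measured compounds in a functional assay on HEK293 cells for activation of melanin-concentrating hormone receptor 1 (Rattus norvegicus), read by inositol phosphate accumulation; a higher number here means that more compound is needed for the effect, a lower number that less compound is needed:
Compound 1 `CC(C)N(C)c1ccc2cc(NC(=O)CCc3ccc(C(F)(F)F)cc3)ccc2n1` gives 140 nM.
Compound 2 `CN(C)c1ccc2cc(NC(=O)CCc3ccc(C(F)(F)F)cc3)ccc2n1` gives 110 nM.

Going by the values given here, of these two numbers, compound 1 has the higher one, but the only step available, a 1.3-fold lower number from compound 1 to compound 2 (0.10 log units; within the scatter), stays within the scatter, so the two compounds cannot be told apart on this assay. Compound 3 `NC1CCN(c2ccc3cc(NC(=O)CCc4ccc(C(F)(F)F)cc4)ccc3n2)C1` is not yet measured. It differs from compound 1 in one place: 3-aminopyrrolidin-1-yl in place of isopropyl(methyl)amino on an aromatic carbon. Among the compounds with values here, the single measured step, the exchange of methyl for isopropyl on the same nitrogen, bears only loosely on this change, since here the whole isopropyl(methyl)amino group gives way to a ring bearing a further nitrogen with a hydrogen-bond donor. That step was small, and nothing measured here shows what the ring or the added donor does. The expectation is therefore a step of uncertain direction and probably modest size, a 1.1-fold higher number from compound 1 to compound 3 (0.03 log units; within the scatter), and compound 3 is estimated at 150 nM within 40 nM to 600 nM.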

Compound 3, half-maximal effective concentration: 200 nM
Beside the measured number, compound 3's estimate is 1.3-fold (0.12 log units) below it; the range from low to high includes it.
By their numbers in this assay, from the lowest: compounds 2, 1 and 3 (each within the scatter of the next).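

In this assay, going by these compounds alone, the aromatic carbon next to the ring nitrogen takes 3-aminopyrrolidin-1-yl with no step that leaves the scatter (a 1.4-fold higher number from compound 1 to compound 3 (0.15 log units; within the scatter); a 1.8-fold higher number from compound 2 to compound 3 (0.26 log units; within the scatter)). The earlier pair differed only in an alkyl group on the nitrogen, whereas this change replaces the whole open-chain amino group with a five-membered non-aromatic ring that adds a hydrogen-bond donor, and compounds 1, 2 and 3 still cannot be told apart. Nothing available here accounts for this result.

From the compounds shown here alone, it remains open what a pyrrolidine ring without the amine would give, or one carrying a hydroxyl group or a carboxylic acid in place of the amine. Going by these compounds, the effect of a six-membered piperazine ring on the same carbon also remains open.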